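A few compounds are considered here, and "the series" means these few. Any claim that something is new, unique, unknown or untested is made for them only; others in the source may bear on it.

Compound 1 `COc1ccc(S(=O)(=O)Nc2cccc3cc[nH]c23)cc1` and compound 2 `Cc1ccc(S(=O)(=O)Nc2cccc3cc[nH]c23)cc1` share one core and differ only in the group carried on their six-membered carbon ring. In a functional assay on KB cells (nasopharynx, Homo sapiens) for antiproliferative activity (a higher number here means a weaker inhibitor, a lower number a stronger inhibitor), compound 1 gives 0.67 ug/mL, while compound 2 gives 2.2 ug/mL. Within the data shown here, compound 2 thus stands highest of the two numbers measured so far, the step being a 3.3-fold higher number from compound 1 to compound 2 (0.52 log units; beyond the scatter). Compound 3 `O=S(=O)(Nc1cccc2cc[nH]c12)c1ccc(Cl)cc1` carries the same core, the change from compound 2 being (chloro in place of methyl on an aromatic carbon). Among the measured compounds shown here, only one measured step bears on this change, and it concerns a different exchange: methyl in place of methoxy, which moved this assay by a 3.3-fold higher number from compound 1 to compound 2 (0.52 log units; beyond the scatter). For the measured compounds named here, no measured pair shows what chloro in place of methyl does here, so the direction of the step is open; a modest change at most is expected, estimated as a 1.5-fold lower number from compound 2 to compound 3 (0.17 log units; within the scatter). For compound 3 the expected value in this assay is therefore 1.5 ug/mL, within a range of 0.5 ug/mL to 4.5 ug/mL.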

Compound 3, half-maximal inhibitory concentration: 6 ug/mL
Beside the measured number, compound 3's estimate is 4.0-fold (0.60 log units) below it; measured number outside the range, above it.
By their numbers in this assay, from the lowest: compound 1; then compound 2; then compound 3.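

Chloro in place of methyl, on an aromatic carbon para to a large group, gives a weaker inhibitor in this assay (a 2.7-fold higher number from compound 2 to compound 3 (0.44 log units; beyond the scatter)). The gap from methoxy is wider still (a 9.0-fold higher number from compound 1 to compound 3 (0.95 log units; beyond the scatter)), so the three groups now form an order at this one position, with methoxy giving the strongest inhibitor, then methyl, then chloro, and every step between them lies beyond the usual scatter. Nothing measured here accounts for this order.

Three groups are too few to show whether another group at this position, such as a hydroxyl, an amine or a longer chain like ethoxy, would match or beat methoxy. On these data alone, whether the same order would hold with these groups elsewhere on the ring also remains open.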